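Morpholine amide to methylamide on the quinolinyl pyridine acrylamide

The source may report more compounds than this note shows. Statements on the series, on what has been measured and on what is new or still open speak of the compounds shown alone.

Measured so far:
- compound 1 `O=C(/C=C/c1ccncc1-c1ccc2ncccc2c1)N1CCOCC1`, 1590 nM
- compound 2 `CNC(=O)CCc1ccncc1-c1ccc2ccccc2c1`, 21.1 nM
- compound 3 `Cn1ccc2cc(-c3cnccc3/C=C/C(=O)N3CCOCC3)ccc21`, 247 nM

In an assay on a protein complex for inhibition of CDK8/Cyclin C (Homo sapiens), with a stated time of 1 h (a higher number here means a weaker inhibitor, a lower number a stronger inhibitor), compound 1 gives 1590 nM, the highest number of the three. Compound 3 sits nearer to it, with 247 nM, and compound 2 furthest, with 21.1 nM; both gaps lie beyond the scatter. Going by the values given here, compound 2 is the only one of the three carrying a methylcarbamoyl group rather than a (morpholin-4-yl)carbonyl group, but it also differs from compound 1 in its chain and its bicyclic ring, so no single step between measured compounds isolates the amide change.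

Compound 4 `CNC(=O)/C=C/c1ccncc1-c1ccc2ncccc2c1` carries the core of compound 1 with methylamino in place of morpholin-4-yl on a carbonyl carbon. The direction of the shift is expected to follow compound 2, whose value 21.1 nM is far lower than that of compound 1, but with the chain and bicycle held as in compound 1 the step is expected to be smaller; the estimated step is a 4.0-fold lower number from compound 1 to compound 4 (0.60 log units; beyond the scatter), beyond the scatter. Compound 4 is therefore expected to give about 400 nM, in the range 120 nM to 1300 nM.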

Compound 4, half-maximal inhibitory concentration: 250 nM
Compound 4: the middle estimate sits 1.6-fold (0.20 log units) above what was measured; the range from low to high includes it.
By their numbers in this assay, from the lowest: compound 2; then compounds 3 and 4 (each within the scatter of the next); then compound 1.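

In this assay, going by these compounds alone, methylamino in place of morpholin-4-yl on a carbonyl carbon gives a 6.4-fold lower number from compound 1 to compound 4 (0.80 log units; beyond the scatter) with the chain and the bicyclic ring held fixed, the first reading of this amide change on its own. The morpholine ring is therefore not needed for inhibition on the core of compound 1, and the change at this one place is enough to move the number beyond the scatter. Heavy-atom count and donor count change together in this step, so the pair cannot tell which of them matters.

Still open, as far as these compounds go, are whether dimethylamino or ethylamino on the same carbonyl carbon behaves like methylamino, and whether the step carries over to the other chain and bicyclic rings. Nothing at hand accounts for the size of the step.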